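Changing the Aryl Group on the Amine Nitrogen

The compounds below may be only part of what the source reports. "The series", "measured", "known", "first", "only" and "open" are said of these compounds alone.

Going by the values given here, compound 2 `Cc1ccc(S(=O)(=O)/N=C(/CCNC2=CC(=O)c3ccccc3C2=O)Nc2cccc(C(F)(F)F)c2)cc1` gives 78500 nM in a functional assay on A549 cells (Homo sapiens) for cytotoxicity, read by MTT assay, with a stated time of 48 h (on this read-out lower numbers stand for stronger inhibition and higher numbers for weaker inhibition), the highest of the two numbers measured so far, while compound 1 `Cc1ccc(S(=O)(=O)/N=C(/CCNC2=CC(=O)c3ccccc3C2=O)Nc2ccccc2I)cc1` gives 24700 nM. Among the compounds with values here, the only step between measured compounds, a 3.2-fold higher number from compound 1 to compound 2 (0.50 log units; beyond the scatter), changes the aryl group on the same amine nitrogen as the move to compound 3 `Cc1ccc(S(=O)(=O)/N=C(/CCNC2=CC(=O)c3ccccc3C2=O)Nc2ccc(F)c(F)c2)cc1`, whose change reads (3,4-difluorophenyl in place of 3-(trifluoromethyl)phenyl on an amine nitrogen). That single step was modest and beyond the scatter, so for compound 3 a modest step toward a lower number is expected in this assay, a 2.0-fold lower number from compound 2 to compound 3 (0.29 log units; within the scatter). Compound 3 is therefore estimated at 40000 nM, within 15000 nM to 110000 nM.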

Compound 3, half-maximal inhibitory concentration: 16700 nM
Compound 3: middle estimate off by 2.4-fold (0.38 log units), on the high side; low and high end bracket the measured number.
By their numbers in this assay, from the lowest: compounds 3 and 1 (each within the scatter of the next); then compound 2.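

In this assay, the change to 3,4-difluorophenyl from 3-(trifluoromethyl)phenyl gives a 4.7-fold lower number from compound 2 to compound 3 (0.67 log units; beyond the scatter), so this position can also move the number downward. The change to 3,4-difluorophenyl from 2-iodophenyl gives a 1.5-fold lower number from compound 1 to compound 3 (0.17 log units; within the scatter), leaving these two groups indistinguishable here, while 3-(trifluoromethyl)phenyl alone stands apart from both. Nothing available explains this difference. From the compounds shown here alone, it remains open how a plain phenyl, a 4-methoxyphenyl or a pyridyl ring on this amine nitrogen would read. Going by these compounds, whether any of these would fall clearly below compound 3 also remains open.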